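This account rests on a few compounds, and the source may have more. Where it says the series, first, only, none or still open, it means among the compounds named here.

Compound 1 `O=c1[nH]cnc2c1c(-c1ccoc1)cn2[C@@H]1O[C@H](CO)[C@@H](O)[C@H]1O` was tested in a functional assay on HeLa S3 cells (Homo sapiens) for antiproliferative activity, read by XTT assay, with a stated time of 72 h; a lower number here means a stronger inhibitor, a higher number a weaker inhibitor. There compound 1 reaches only the limit of > 20000 nM, so no number is known for it. Compound 2 `O=c1[nH]cnc2c1c(-c1cccs1)cn2[C@@H]1O[C@H](CO)[C@@H](O)[C@H]1O` differs from compound 1 in that (thiophen-2-yl in place of furan-3-yl on an aromatic carbon). In this assay compound 2 likewise stops at the limit of > 20000 nM. The step that the two limits leave unreadable from compound 1 to compound 2 is therefore unreadable, as both compounds sit at the limit of > 20000 nM in this assay, at which 2 of the 3 values shown sit. Compound 3 `CSc1ncnc2c1c(-c1ccoc1)cn2[C@@H]1O[C@H](CO)[C@@H](O)[C@H]1O` carries a different core from compound 1; the difference between the two cores is not broken down here. In this assay, within the data shown here, compound 3 gives 5390 nM, the only number among the three measured values. Compound 4 `CSc1ncnc2c1c(-c1cccs1)cn2[C@@H]1O[C@H](CO)[C@@H](O)[C@H]1O` is not yet measured. It differs from compound 3 in that (thiophen-2-yl in place of furan-3-yl on an aromatic carbon), the same change as from compound 1 to compound 2, at a place described in the same words. Because the step that the two limits leave unreadable from compound 1 to compound 2 is unreadable, the expectation for compound 4 rests on compound 3 alone, which gives 5390 nM. The step is expected to be a 1.0-fold higher number from compound 3 to compound 4 (0.01 log units; within the scatter). Compound 4 is thus expected to give about 5500 nM, between 1800 nM and 20000 nM.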

Compound 4, half-maximal inhibitory concentration: 1960 nM
Compound 4: the middle estimate sits 2.8-fold (0.45 log units) above what was measured; the range from low to high includes it.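

In this assay, placing thiophen-2-yl where furan-3-yl stood on the core of compound 3 gives a 2.8-fold lower number from compound 3 to compound 4 (0.44 log units; beyond the scatter). On the core of compound 1 the same change cannot be read, as compound 1 and compound 2 both give only a limit and not a number: the limit of > 20000 nM in this assay, at which 2 of the 4 values shown sit. The change therefore has one readable step, on one core, which shows that it can matter on the core of compound 3 but not whether its direction or size carries over to the core of compound 1.

The compounds shown leave open whether another group on the same aromatic carbon, such as phenyl or an aminomethyl group, would take the number further in either direction on the core of compound 3. They also leave open whether a thiophen-3-yl group would behave like thiophen-2-yl, and whether any group at this place could bring the core of compound 1 to a measurable value.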